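Swapping the aromatic amine for a methyl on the ketone side

This account rests on a few compounds, and the source may have more. Where it says the series, first, only, none or still open, it means among the compounds named here.

Of the compounds shown here, three sharing one core have been tested in a functional assay on A549 cells (Homo sapiens) for antiproliferative activity, read by MTT assay, with a stated time of 48 h; a lower number here means a stronger inhibitor, a higher number a weaker inhibitor. Compound 1 `CCOc1ccc(C(=O)/C=C/c2c(/C=C/c3ccc(OC)cc3)cc(OC)cc2OC)cc1` gives 7.5 ug/mL in this assay, and compound 2 `CCCCCCOc1ccc(C(=O)/C=C/c2c(/C=C/c3ccc(OC)cc3)cc(OC)cc2OC)cc1` gives 8.4 ug/mL, the two differing by a 1.1-fold higher number from compound 1 to compound 2 (0.05 log units; within the scatter). Compound 3 `COc1ccc(/C=C/c2cc(OC)cc(OC)c2/C=C/C(=O)c2ccc(N)cc2)cc1` gives the lowest of the three numbers in this assay, 3.8 ug/mL; its nearest neighbour is compound 1, a step of a 2.0-fold lower number from compound 1 to compound 3 (0.30 log units; within the scatter), and its furthest is compound 2, a step of a 2.2-fold lower number from compound 2 to compound 3 (0.34 log units; beyond the scatter).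

Compound 4 `COc1ccc(/C=C/c2cc(OC)cc(OC)c2/C=C/C(=O)c2ccc(C)cc2)cc1` is the next analogue, not yet measured. It differs from compound 3 only as follows: methyl in place of amino on an aromatic carbon Both measured steps that bear on this position involve the amino group of compound 3, and both are small: replacing an alkoxy group with amino moved the number by a 2.0-fold lower number from compound 1 to compound 3 (0.30 log units; within the scatter) and by a 2.2-fold lower number from compound 2 to compound 3 (0.34 log units; beyond the scatter). For the measured compounds named here, no measured step involves a methyl at this position, so the expectation rests on the observation that changes here have so far been modest.

The step to compound 4 is therefore expected to be small in this assay, namely a 1.6-fold higher number from compound 3 to compound 4 (0.20 log units; within the scatter). That would leave it near the numbers of compounds 1 and 2. Compound 4 is estimated to give 6 ug/mL in this assay, within a range from 3 ug/mL to 12 ug/mL.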

Compound 4, half-maximal inhibitory concentration: 3.6 ug/mL
Compound 4: the middle estimate sits 1.7-fold (0.22 log units) above what was measured, and the stated range covers the measured number.
By their numbers in this assay, from the lowest: compounds 4, 3, 1 and 2 (each within the scatter of the next, the first and the last beyond it).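

In this assay, the step of a 1.1-fold lower number from compound 3 to compound 4 (0.02 log units; within the scatter) shows that the amino group at this place can give way to methyl, losing the hydrogen-bond donor and acceptor counted on it, with no change beyond the scatter, so in this pair those features are not required for the read-out. Methyl also makes the contrast with the alkoxy compounds clearer: the steps of a 2.1-fold lower number from compound 1 to compound 4 (0.32 log units; beyond the scatter) and a 2.3-fold lower number from compound 2 to compound 4 (0.37 log units; beyond the scatter) both lie beyond the scatter, though they are modest, while the amino compound stayed within it against the ethoxy compound, with a 2.0-fold lower number from compound 1 to compound 3 (0.30 log units; within the scatter) as the one step that does not fully fit this pattern. Nothing available here explains why amino and methyl read alike or why both differ from the longer alkoxy groups.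

The compounds shown leave open how a bare hydrogen, a chlorine or a methoxy group would read at this place, and so whether the oxygen or the chain of the alkoxy groups separates compounds 1 and 2 from compounds 3 and 4. They also leave open whether methyl and amino would still match on a different cell line.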